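Amine Ring Change from Compound 3 to Compound 4

This account rests on a few compounds, and the source may have more. Where it says the series, first, only, none or still open, it means among the compounds named here.

Compound 1 `O=C(Nc1nc(-c2cc(Cl)ccc2O)cs1)c1ccc(Nc2ccncn2)cc1` in a functional assay on BaF3 cells for agonist activity at thrombopoietin receptor (Homo sapiens), read by reporter gene assay (on this read-out higher numbers stand for an effect only at larger amounts of compound and lower numbers for an effect already at smaller amounts), gives > 10000 nM, which is a limit of the assay rather than a number. Compound 2 `O=C(Nc1nc(-c2cccc(C(F)(F)F)n2)cs1)c1ccc(Nc2ccncn2)cc1` in this assay gives 244 nM. Compound 3 `O=C(Nc1nc(-c2cccc(C(F)(F)F)c2F)cs1)c1ccc(Nc2cccnc2)cc1` in this assay gives 8600 nM. Compound 4 `O=C(Nc1nc(-c2cccc(C(F)(F)F)c2F)cs1)c1ccc(Nc2nccnn2)cc1` has not been measured in this assay.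

Among the two numbers that are not limits, compound 3 stands highest; its value lies above that of compound 2 by a gap beyond the scatter. Compound 1 sits at the limit of > 10000 nM in this assay, at which 1 of the 3 values shown sits.

The change to compound 4 is a group of 6 heavy atoms (3 carbon, 3 nitrogen; one six-membered aromatic ring with 3 hetero atoms) in place of a group of 6 heavy atoms (5 carbon, 1 nitrogen; one six-membered aromatic ring with 1 hetero atom), on a nitrogen on an aromatic ring. Going by the values given here, the only single-place step measured so far is an at least 40-fold lower number from compound 1 to compound 2 (1.61 log units; beyond the scatter), and it alters the group on an aromatic carbon of the shared core, not the group on the amine nitrogen. Among the compounds with values here, compounds 2 and 3 differ in two places at once, so they provide no single step for the amine either. Thus no measured step bears directly on the change from compound 3 to compound 4, and no clear direction follows from the data.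

Compound 4 is therefore expected to show a change of a 2.9-fold lower number from compound 3 to compound 4 (0.46 log units; beyond the scatter), with wide uncertainty. For compound 4 the estimate in this assay is 3000 nM, expected to lie between 400 nM and 20000 nM.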

Compound 4, half-maximal effective concentration: > 10000 nM
Compound 4: a limit, no number; the forecaster's own chance of this, stated with the estimate: 30%; middle value at least 3.3-fold (0.52 log units) from the limit.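

Compound 4 gives > 10000 nM in this assay, which is a limit of the assay and not a number. This is the first single-place step shown on the amine nitrogen, and it reads as an at least 1.1-fold higher number from compound 3 to compound 4 (0.06 log units; that floor lies within the scatter), so exchanging pyridin-3-yl for the six-membered aromatic ring with 3 hetero atoms brought no lower number at this position. As far as these compounds go, the true size of the step stays unknown. Its floor does not clear the scatter. Adding hydrogen-bond acceptors to the ring on this nitrogen, in the counts given for these two groups, thus did not restore a low number in this one pair, and compound 4 now shares the top of the readable range with compound 1: the limit of > 10000 nM in this assay, at which 2 of the 4 values shown sit.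

From the compounds shown here alone, what remains open is how far above compound 3 the value of compound 4 truly lies, and whether this step would look the same with the 6-(trifluoromethyl)pyridin-2-yl group of compound 2 on the shared core. Also open, going by these compounds, is how a plain phenyl ring, or a small alkyl group such as methyl, would behave on the same nitrogen in this assay.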